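Swapping fluoro for chloro on a chalcone side chain

The source may hold more compounds than are shown below. What is called first, only, known or untested is meant among the compounds shown, and "the series" means these compounds.

Measured compounds:
- compound 1 (`CNC(=O)c1cc(Oc2ccc(/C=C/C(=O)c3ccc([N+](=O)[O-])cc3)cc2)ccn1`): "not determined" (no result reported) in a functional assay on PC-3 cells (Homo sapiens) for cytotoxicity, read by MTT assay, with a stated time of 72 h; a higher number here means a weaker inhibitor, a lower number a stronger inhibitor
- compound 2 (`CNC(=O)c1cc(Oc2ccc(C(=O)/C=C/c3ccc(F)cc3Cl)cc2)ccn1`): 4760 nM in this assay
- compound 3 (`CNC(=O)c1cc(Oc2ccc(/C=C/C(=O)c3ccc(C)cc3)cc2)ccn1`): "not determined" (no result reported) in this assay

Only compound 2 carries a number in this assay; compound 1 and compound 3 share the same core but were left without a result, so nothing can be said about how the three compare. Compound 2 therefore stands alone as the sole reference point.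

The next compound, compound 4 (`CNC(=O)c1cc(Oc2ccc(C(=O)/C=C/c3ccc(Cl)cc3Cl)cc2)ccn1`), differs from compound 2 in one place: chloro in place of fluoro on an aromatic carbon. Read one bond further out, the change is 2-chloro-4-fluorophenyl to 2,4-dichlorophenyl. Within the data shown here, no pair of measured compounds shows what such a swap does here, so there is no measured step to lean on.

A change of one halogen for another on an aromatic carbon is a small one, and the expected step of a 1.4-fold lower number from compound 2 to compound 4 (0.13 log units; within the scatter) is not beyond the usual scatter, with perhaps a slight lean toward a stronger inhibitor. Compound 4 is thus estimated at 3500 nM, with a range from 1500 nM to 9000 nM.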

Compound 4, half-maximal inhibitory concentration: 9220 nM
Compound 4: middle estimate off by 2.6-fold (0.42 log units), on the low side; measured number above the stated range.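

In this assay this position, para to a large group and meta to a chloro group, now has one measured step, a 1.9-fold higher number from compound 2 to compound 4 (0.29 log units; within the scatter). Fluoro and chloro therefore cannot be told apart here, since a gap of this size could arise from repeating the same measurement. Among these compounds, this finding covers only this one pair of halogens on this one side chain, and nothing measured on either compound offers an explanation for the result.

The compounds shown leave open whether a group of a different kind at this position, such as an amine, a methoxy group or a carboxylic acid, would move the number beyond the scatter. Steps involving compound 1 and compound 3 cannot be read, so the nitro and methyl groups they carry add nothing to this comparison.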